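The source may report more compounds than this note shows. Statements on the series, on what has been measured and on what is new or still open speak of the compounds shown alone.

Measured compounds in an ADME assay on the whole organism (plasma) for pharmacokinetics, with Rattus norvegicus as the target, at a dose of 5 mg/kg by the oral route; on this read-out lower numbers stand for lower exposure and higher numbers for higher exposure at the dose given:
compound 1 `CC[C@H](C)[C@@H]1C(=O)N[C@H](C2Cc3ccccc3C2)C(=O)N1[C@@H](C(=O)N(C)C)c1ccc(C)[n+]([O-])c1` gives 24 ng.h/mL
compound 2 `CC[C@H](C)[C@@H]1C(=O)N[C@H](C2Cc3ccccc3C2)C(=O)N1[C@@H](C(=O)N1CCOCC1)c1ccc(C)nc1` gives 1450 ng.h/mL
compound 3 `CC(C)C[C@@H]1C(=O)N[C@H](C2Cc3ccccc3C2)C(=O)N1[C@@H](C(=O)N(C)C)c1ccc(N(C)C)nc1` gives 135 ng.h/mL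

Compound 2 stands highest of the three numbers in this assay. Its nearest neighbour is compound 3, whose value is well beyond the scatter below it; compound 1 lies furthest, also beyond the scatter. Going by the values given here, the three measured compounds each differ from one another in more than one place, so no single-change step among them is available to guide the next compound.

Compound 4 `CCC(CC)[C@@H]1C(=O)N[C@H](C2Cc3ccccc3C2)C(=O)N1[C@@H](C(=O)N1CCOCC1)c1ccc(C)nc1` differs from compound 2 in one place: pentan-3-yl in place of sec-butyl on a saturated ring carbon on a saturated ring carbon. The leaving and entering groups count no donors, no acceptors and no ring, and differ by one carbon. Among the compounds with values here, with no measured precedent for this change, the step from compound 2 to compound 4 is expected to be small, with direction uncertain, and most likely no larger than the usual scatter, estimated as a 1.5-fold lower number from compound 2 to compound 4 (0.16 log units; within the scatter). Compound 4 is therefore expected to give about 1000 ng.h/mL in this assay, within a range of 300 ng.h/mL to 3000 ng.h/mL.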

Compound 4, area under the concentration-time curve: 1380 ng.h/mL
Estimate against measurement, compound 4: 1.4-fold (0.14 log units) below, within the range that was stated.
By their numbers in this assay, from the lowest: compound 1; then compound 3; then compounds 4 and 2 (each within the scatter of the next).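

Pentan-3-yl in place of sec-butyl on the saturated ring carbon gives a 1.1-fold lower number from compound 2 to compound 4 (0.02 log units; within the scatter) in this assay and this lies within the scatter, making it the first single-change step readable in the series. With the other groups of compound 2 in place, this position therefore takes one added carbon and the loss of the defined stereocentre of sec-butyl without a readable change in exposure. Nothing measured on these compounds accounts for the size of this step.

As far as these compounds go, whether exposure holds with a cyclohexyl ring, a longer chain or a hydroxyl-bearing chain on this carbon stays open. Equally open, from the compounds shown here alone, is whether the step would stay this small alongside the other groups that compound 1 and compound 3 carry on the shared core.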